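Moving the trifluoromethoxy group around the phenyl ring

This account rests on a few compounds, and the source may have more. Where it says the series, first, only, none or still open, it means among the compounds named here.

Three compounds share a core in which a substituted phenyl ring hangs from a six-membered ring with two nitrogens. Compound 1 `Cc1cnc(Nc2ccc3[nH]ncc3c2)nc1-c1ccc(OC(F)(F)F)cc1` in an assay on NIH3T3 cells for inhibition of Sonic hedgehog protein (Mus musculus), read by a luciferase reporter, with a stated time of 48 h (a lower number here means a stronger inhibitor, a higher number a weaker inhibitor), gives 125 nM. Compound 2 `Cc1cnc(Nc2ccc(C(=O)Nc3c(C)cccc3C)cc2)nc1-c1ccc(OC(F)(F)F)cc1`, which carries an amide-linked dimethylphenyl group instead of the fused bicyclic ring, gives 1.3 nM in this assay. Compound 3 `Cc1cnc(Nc2ccc(C(=O)Nc3c(C)cccc3C)cc2)nc1-c1cccc(OC(F)(F)F)c1` gives 1.2 nM in this assay. Compound 3 thus has the lowest number of the three, though compound 2 lies within the scatter of it, while compound 1 sits well above both.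

Compound 4 `Cc1cnc(Nc2ccc(C(=O)Nc3c(C)cccc3C)cc2)nc1-c1ccccc1OC(F)(F)F` has not yet been measured. The change from compound 3 is 2-(trifluoromethoxy)phenyl in place of 3-(trifluoromethoxy)phenyl on an aromatic carbon. Among the compounds with values here, the only step that bears on it is a 1.1-fold lower number from compound 2 to compound 3 (0.03 log units; within the scatter), which shows that moving the trifluoromethoxy group from one position to another on this phenyl ring left the number unchanged. On that evidence alone a similarly small step is expected, with some allowance for an unknown direction: compound 4 is estimated at 3 nM in this assay, within 0.8 nM to 12 nM, which is expected to be a 2.5-fold higher number from compound 3 to compound 4 (0.40 log units; beyond the scatter).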

Compound 4, half-maximal inhibitory concentration: > 500 nM
Compound 4: only a limit was reported; the forecaster's own chance of this, stated with the estimate: 0%; middle value at least 160-fold (2.22 log units) from the limit.
By their numbers in this assay, from the lowest: compounds 3 and 2 (each within the scatter of the next); then compound 1. At a limit, above all of these: compound 4.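

Compound 4 gives > 500 nM in this assay, which is a limit of the assay and not a number. Placement on this phenyl ring can matter after all: the change to 2-(trifluoromethoxy)phenyl gives an at least 410-fold higher number from compound 3 to compound 4 (2.61 log units; beyond the scatter) and an at least 380-fold higher number from compound 2 to compound 4 (2.58 log units; beyond the scatter), both large and beyond the scatter, whereas the earlier step between the other two placements lay within it. The groups exchanged hold the same atoms, joined differently, so among compounds 2, 3 and 4 only the place of the trifluoromethoxy group separates the 2-(trifluoromethoxy)phenyl compound from the other two.

The compounds shown leave open whether a fluorine atom or a methoxy group in the same place would give a similar loss. They also do not show what causes the loss.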